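The source may report more compounds than this note shows. Statements on the series, on what has been measured and on what is new or still open speak of the compounds shown alone.

Measured so far:
compound 1, `O=C(CCSc1nc2cc(Cl)ccc2o1)N1CCC1`, 3.7 mL/min/g in an ADME assay on microsomes from liver (Homo sapiens) for metabolic stability, read by LC-MS, using NADPH, with a stated time of 45 min, tested at 0.5 uM; a lower number here means slower removal, a higher number faster removal of the compound
compound 2, `CN1CCN(C(=O)CCSc2nc3cc(Cl)ccc3o2)CC1`, 1.5 mL/min/g in this assay

For the measured compounds named here, compound 2 gives the lowest number of the two, and the single measured step, a 2.5-fold lower number from compound 1 to compound 2 (0.39 log units; beyond the scatter), lies beyond the scatter. Compound 3, `CC1CCN(C(=O)CCSc2nc3cc(Cl)ccc3o2)C1`, is not yet measured; the change from compound 2 is 3-methylpyrrolidin-1-yl in place of 4-methylpiperazin-1-yl on a carbonyl carbon. Going by the values given here, the only step that bears on it is the one from compound 1 to compound 2, where a ring with one nitrogen was exchanged for one with two nitrogens and one hydrogen-bond acceptor, and the number fell. Compound 3 returns to a ring with one nitrogen and no hydrogen-bond acceptor, so the expectation is a move back up, of roughly the same size as that step, rather than no change. The estimated step is a 3.0-fold higher number from compound 2 to compound 3 (0.48 log units; beyond the scatter). For compound 3 the expected value is 4.5 mL/min/g, with a range from 2 mL/min/g to 10 mL/min/g.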

Compound 3, intrinsic clearance in a liver preparation (reported as CLH), per the amount of preparation that the assay uses: 10.1 mL/min/g
Compound 3: middle estimate off by 2.2-fold (0.35 log units), on the low side; measured number above the stated range.
By their numbers in this assay, from the lowest: compound 2; then compound 1; then compound 3.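

At this place on the carbonyl carbon, the choice of ring moves the number in this assay further than the first pair showed, with a 6.7-fold higher number from compound 2 to compound 3 (0.83 log units; beyond the scatter) set against a 2.5-fold lower number from compound 1 to compound 2 (0.39 log units; beyond the scatter) for the earlier exchange. The number also shifts without 4-methylpiperazin-1-yl being involved, since a 2.7-fold higher number from compound 1 to compound 3 (0.44 log units; beyond the scatter) separates the other two rings, so that group is not the only one that matters here. Nothing measured here explains these differences.

Still open, going by these compounds, is whether the methyl group or the five-membered ring accounts for the high number of compound 3, which plain pyrrolidin-1-yl would help to separate. Also open, on these data alone, is whether the low number of compound 2 follows the nitrogen atoms of its ring or the six-membered ring itself, a question for piperidin-1-yl and morpholin-4-yl.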